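Swapping the Sulfinyl Chain of Compound 1 for a Pentenol

The compounds below may be only part of what the source reports. "The series", "measured", "known", "first", "only" and "open" are said of these compounds alone.

Measured so far:
compound 1, `CC(C)Cn1c(=O)n(C)c(=O)c2nc([S+]([O-])CCCO)c(Cc3cccc4ccccc34)nc21`, in a functional assay on Raji cells (Homo sapiens) for inhibition, read by MTT assay, with a stated time of 96 h (a lower number here means that less compound is needed, a higher number that more compound is needed for the effect), gives 1990 nM
compound 2, `CC(C)Cn1c(=O)n(C)c(=O)c2nc(-c3[nH]nnc3CCCO)c(Cc3cccc4ccccc34)nc21`, in this assay gives 6020 nM

Compound 1 has the lowest of the two numbers shown in this assay; its nearest neighbour is compound 2, and the step of a 3.0-fold higher number from compound 1 to compound 2 (0.48 log units; beyond the scatter) is modest but beyond the scatter. Within the data shown here, that one step is the only comparison available, and it concerns a different change from the one now in question.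

Compound 3, `CC(C)Cn1c(=O)n(C)c(=O)c2nc(/C=C\CCCO)c(Cc3cccc4ccccc34)nc21`, keeps the shared core of compound 1 and differs in a single place: a group of 6 heavy atoms (5 carbon, 1 oxygen; no ring) in place of a group of 6 heavy atoms (3 carbon, 2 oxygen, 1 sulfur; no ring), on an aromatic carbon. The chain that enters is of the same heavy-atom count as the one that leaves. The step from compound 1 to compound 2 shows that replacing this group on the aromatic carbon can cost potency, but it does not say how a pentenol chain will behave. The expectation for compound 3 is therefore a number close to that of compound 1, with a wide range, and the expected step of a 1.5-fold higher number from compound 1 to compound 3 (0.18 log units; within the scatter) is estimated as small. Compound 3 is expected to give about 3000 nM in this assay, within 1000 nM to 9000 nM.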

Compound 3, half-maximal effective concentration: 70 nM
For compound 3 the middle estimate is 43-fold (1.63 log units) above the measured one, and the stated range ends above it.
By their numbers in this assay, from the lowest: compound 3; then compound 1; then compound 2.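

In this assay, among these compounds, 5-hydroxypent-1-en-1-yl in place of the sulfinyl chain gives a 28-fold lower number from compound 1 to compound 3 (1.45 log units; beyond the scatter) and so shows for the first time that a change on this aromatic carbon, next to the ring nitrogen, can lower the number substantially, since the only earlier step had raised it. The chains that leave and enter have the same count of heavy atoms, so the large shift comes with a change in their makeup and not in that count. The step of an 86-fold lower number from compound 2 to compound 3 (1.93 log units; beyond the scatter) is larger still and sets the open-chain alkene well apart from the triazole-bearing group at this place, while no measurement here gives a reason for either step.

The compounds shown leave open whether the double bond itself matters, as neither the saturated 5-hydroxypentyl chain nor the other double-bond geometry appears among them. They also leave open whether the terminal hydroxyl can give way to an amine or a carboxylic acid, and how a shorter or longer chain would behave at this position.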